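The source may hold more compounds than are shown below. What is called first, only, known or untested is meant among the compounds shown, and "the series" means these compounds.

Series notes. Going by the values given here, in a functional assay on M21 cells (Homo sapiens) for antiproliferative activity, read by sulforhodamine B assay, with a stated time of 48 h (on this read-out lower numbers stand for stronger inhibition of growth and higher numbers for weaker inhibition of growth), compound 1 `NS(=O)(=O)NCCC1CCN(c2cc(-c3ccc(Cl)cc3)ncn2)CC1` gives 45200 nM, and compound 2 `NS(=O)(=O)NCCC1CCN(c2cc(-c3ccc(C(F)(F)F)cc3)ncn2)CC1` gives 34800 nM; the only step, a 1.3-fold lower number from compound 1 to compound 2 (0.11 log units; within the scatter), stays within the scatter, so compound 2 and compound 1 cannot be ordered on these two numbers. Compound 3 `CCOC(=O)c1ccc(-c2cc(N3CCC(CCNS(N)(=O)=O)CC3)ncn2)cc1` is not yet measured. The change is ethoxycarbonyl in place of trifluoromethyl on an aromatic carbon. Among the compounds with values here, no measured step exchanges a para substituent for an ethoxycarbonyl group; the one known step bears only loosely on it and was within the scatter, so for this assay no step beyond the scatter is expected, a 1.1-fold higher number from compound 2 to compound 3 (0.06 log units; within the scatter). Compound 3 is therefore estimated at 40000 nM, with a range of 15000 nM to 100000 nM.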

Compound 3, concentration for 50% growth inhibition: 9000 nM
Compound 3: middle estimate off by 4.4-fold (0.65 log units), on the high side, and the stated range ends above it.
By their numbers in this assay, from the lowest: compound 3; then compounds 2 and 1 (each within the scatter of the next).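

In this assay, the group on this aromatic carbon now shifts the read-out beyond the scatter, which the exchange of chloro for trifluoromethyl did not do (a 3.9-fold lower number from compound 2 to compound 3 (0.59 log units; beyond the scatter); a 5.0-fold lower number from compound 1 to compound 3 (0.70 log units; beyond the scatter)). Compound 3 thus has the lowest number of the three, so the position does respond to the group it carries, though only modestly. Nothing measured here accounts for this difference.

From the compounds shown here alone, whether the ester itself matters remains open. A carboxylic acid, a primary amide or a longer alkyl ester at this position would help separate the carbonyl from the ethyl part.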